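The source may hold more compounds than are shown below. What is called first, only, known or untested is meant among the compounds shown, and "the series" means these compounds.

Measured in an ADME assay on microsomes from liver (Mus musculus) for metabolic stability, read by LC-MS, using NADPH, with a stated time of 30 min, tested at 0.1 uM, in the presence of a further agent that is not named here; a lower number here means that less of the compound is left, a higher number that more of the compound is left:
- compound 1 `Nc1ncc(-c2ccc(C(=O)N3CC(O)C3)cc2)nc1-c1ccc(C(F)(F)F)cc1`: > 90%
- compound 2 `Nc1ncc(-c2ccc(C(=O)N3CC[C@H](O)C3)cc2)nc1-c1ccc(C(F)(F)F)cc1`: > 90%

Both values are limits and not numbers. Compound 2 stands at > 90%, and this limit is all that is known of its place. Compound 3 `Nc1ncc(-c2ccc(C(=O)N3CCC(O)CC3)cc2)nc1-c1ccc(C(F)(F)F)cc1` carries the change 4-hydroxypiperidin-1-yl in place of 3-hydroxypyrrolidin-1-yl on a carbonyl carbon. Among the compounds with values here, the only measured step bearing on it is a step that the two limits leave unreadable from compound 1 to compound 2. The evidence so far is the limit of > 90% in this assay, at which 2 of the 2 values shown sit. As far as these compounds go, no step beyond the scatter is therefore expected in this assay, and the direction stays open. The estimated step is a number no higher from compound 2 to compound 3 (the limit leaves the size open). Compound 3 is expected at 90%, within an estimated range of 75% to 100%.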

Compound 3, percent of the compound remaining: > 90%
Compound 3: a limit, no number; the forecaster's own chance of this, stated with the estimate: 50%; the middle value sits exactly at the limit.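

In this assay compound 3 gives > 90%, a limit and not a number. Within the data shown here, no step among compound 1, compound 2 and compound 3 can be read. The compounds shown leave open whether changing the hydroxylated ring on the carbonyl carbon alters the percent remaining at all.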